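This account rests on a few compounds, and the source may have more. Where it says the series, first, only, none or still open, it means among the compounds named here.

Working notes on the series

In a functional assay on HepG2 cells (Homo sapiens) for antiproliferative activity, read by CCK-8 assay, with a stated time of 72 h (on this read-out lower numbers stand for stronger inhibition and higher numbers for weaker inhibition), compound 1 `O=C(/C=C/c1ccc(COc2ccccc2)cc1)NO` gives 8400 nM. Compound 2 `O=C(/C=C/c1ccc(CN2CCc3ccccc32)cc1)NO` gives 14900 nM in this assay, and compound 3 `Nc1cc(F)ccc1NC(=O)c1ccc(COc2ccccc2)cc1` gives 7020 nM. The number for compound 1 is the second highest of the three, but its gap to compound 3 and its gap to compound 2 both lie within the usual scatter, so none of the three can be set apart from the others on these data. Among the measured compounds shown here, no measured pair in the set differs in a single place, so no step can be read off directly.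

Compound 4 `O=C(NO)c1ccc(COc2ccccc2)cc1` has not yet been measured in this assay. It differs from compound 1 in one place: hydroxycarbamoyl in place of 2-(hydroxycarbamoyl)ethenyl on an aromatic carbon. The change shortens the group that carries the hydroxamic acid while the rest of the molecule is kept. For the measured compounds named here, with no measured analogue of this change in the set, the expectation rests on the structures alone. A modest weakening, somewhat beyond the scatter but not large, is expected for the step of a 2.4-fold higher number from compound 1 to compound 4 (0.38 log units; beyond the scatter). Compound 4 is therefore estimated at 20000 nM in this assay, with an expected range from 7000 nM to 55000 nM.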

Compound 4, half-maximal inhibitory concentration: 29600 nM
Compound 4: middle estimate off by 1.5-fold (0.17 log units), on the low side, and the stated range covers the measured number.
By their numbers in this assay, from the lowest: compounds 3, 1, 2 and 4 (each within the scatter of the next, the first and the last beyond it).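

In this assay, among the compounds shown here, hydroxycarbamoyl in place of 2-(hydroxycarbamoyl)ethenyl on an aromatic carbon gives a 3.5-fold higher number from compound 1 to compound 4 (0.55 log units; beyond the scatter), the first single change at this position to read beyond the scatter, so the number here depends on which of these two groups the ring carries. The other single change reaching compound 4, hydroxy in place of 2-amino-4-fluorophenyl on an amide-type nitrogen, gives a 4.2-fold higher number from compound 3 to compound 4 (0.62 log units; beyond the scatter), so compound 4 sits modestly above both neighbours, and the short hydroxycarbamoyl group matches neither of the two longer arrangements. Nothing available explains either step.

Still open, going by these compounds, is whether the number of compound 1 depends on the double bond or on chain length, which a saturated 2-(hydroxycarbamoyl)ethyl group or a longer chain in the same place would separate. Also open, on these data alone, is whether a carboxylic acid or a primary amide in place of hydroxycarbamoyl would give a number near that of compound 4, and whether the same shortening would cost as much with the other end of compound 2 in place.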